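A Phenyl Added to the Weakest Compound

The source may report more compounds than this note shows. Statements on the series, on what has been measured and on what is new or still open speak of the compounds shown alone.

Measured in a functional assay on A2780 cells (Homo sapiens) for antiproliferative activity, read by MTT assay, with a stated time of 72 h (on this read-out higher numbers stand for weaker inhibition and lower numbers for stronger inhibition), are these values
- compound 1 `CCNC(=O)NOCc1ccc(/C=C/C(=O)NO)cc1` gives 35400 nM
- compound 2 `O=C(/C=C/c1ccc(CONC(=O)Nc2ccccc2)cc1)NO` gives 112000 nM
- compound 3 `COc1ccc(NC(=O)NOCc2ccc(/C=C/C(=O)NO)cc2)cc1` gives 1150 nM

Compound 2 has the highest number of the three, which makes it the weakest inhibitor here. Both of its gaps lie beyond the scatter: a 3.2-fold higher number from compound 1 to compound 2 (0.50 log units; beyond the scatter) and a 97-fold lower number from compound 2 to compound 3 (1.99 log units; beyond the scatter).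

Compound 4 `O=C(/C=C/c1ccc(CONC(=O)Nc2ccccc2-c2ccccc2)cc1)NO` has not yet been measured. It differs from compound 2 in one place, with phenyl in place of hydrogen on an aromatic carbon.

The closest guide is the other change made on an aromatic carbon of compound 2. Methoxy in place of hydrogen gave the large step of a 97-fold lower number from compound 2 to compound 3 (1.99 log units; beyond the scatter). Phenyl is a different group, however, and no measured compound carries an added phenyl, so this precedent is loose. The modest step of a 3.2-fold higher number from compound 1 to compound 2 (0.50 log units; beyond the scatter) shows that a number can also rise when phenyl replaces ethyl on an amide-type nitrogen, a change at a different place. A move to a lower number in this assay is therefore expected, though a smaller one than methoxy gave.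

The estimated step is a 5.6-fold lower number from compound 2 to compound 4 (0.75 log units; beyond the scatter). For compound 4 the expected value is 20000 nM, with an estimated range of 2500 nM to 120000 nM.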

Compound 4, half-maximal inhibitory concentration: 3570 nM
The estimate for compound 4 lay 5.6-fold (0.75 log units) above the measured number; the measured number falls inside the stated range.
By their numbers in this assay, from the lowest: compound 3; then compound 4; then compound 1; then compound 2.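

In this assay, adding a phenyl ring to an aromatic carbon of compound 2, ortho to a large group, gives a large improvement: a 31-fold lower number from compound 2 to compound 4 (1.50 log units; beyond the scatter). Until now, methoxy was the only group shown to lower the number from an aromatic carbon of compound 2, and phenyl now does so as well, even though it contains only carbon and counts 0 hydrogen-bond donors and 0 hydrogen-bond acceptors. Phenyl therefore has opposite outcomes in the two changes shown: it raises the number when it replaces ethyl on an amide-type nitrogen, a 3.2-fold higher number from compound 1 to compound 2 (0.50 log units; beyond the scatter), and lowers it here on an aromatic carbon. No measurement shown here explains why the added phenyl lowers the number.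

These compounds leave open whether a small group such as methyl, or an amine, at this same place would also lower the number, or whether a ring as large as phenyl is needed. They also leave open how much the place itself matters, as no compound shown carries phenyl on a different carbon of this aromatic ring.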